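The compounds below may be only part of what the source reports. "The series", "measured", "known", "first", "only" and "open" are said of these compounds alone.

Cytotoxicity numbers in a functional assay on HepG2 cells (Homo sapiens) for cytotoxicity (a higher number here means a weaker inhibitor, a lower number a stronger inhibitor), so far:
compound 1 `N#C/N=C1\N(CCCCCCOc2ccc(Cl)cc2)C(=O)CN1c1ccncc1`, 392 nM
compound 2 `CCC1C(=O)N(CCCCCOc2ccc(Cl)cc2)/C(=N\C#N)N1c1ccncc1`, 4320 nM
compound 3 `CCC1C(=O)N(CCCCCCOc2ccc(Cl)cc2)/C(=N\C#N)N1c1ccncc1`, 4350 nM

Among the three, compound 3 and compound 2 sit together at the high end of the range, with a 1.0-fold higher number from compound 2 to compound 3 (0.00 log units; within the scatter); the chain-length change between them leaves the number unmoved. Compound 1 stands well apart: an 11-fold higher number from compound 1 to compound 3 (1.05 log units; beyond the scatter), so ethyl in place of hydrogen on the saturated ring carbon of the shared core pushed the number a long way upward.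

Compound 4 `N#C/N=C1\N(CCCCCCOc2ccc(Cl)cc2)C(=O)C(c2ccccc2)N1c1ccncc1` is the next step on that same carbon: phenyl in place of ethyl on a saturated ring carbon. For the measured compounds named here, only one measured step bears on this position, an 11-fold higher number from compound 1 to compound 3 (1.05 log units; beyond the scatter), and it shows the position to be sensitive to substitution. Going by the values given here, no measured pair speaks to phenyl against ethyl, so the direction is open; a further rise is as plausible as a partial return. The working expectation is a small upward step, a 1.4-fold higher number from compound 3 to compound 4 (0.14 log units; within the scatter), with wide uncertainty. Compound 4 is therefore estimated at 6000 nM, within 1500 nM to 20000 nM.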

Compound 4, half-maximal inhibitory concentration: 44 nM
Compound 4: the middle estimate sits 140-fold (2.13 log units) above what was measured; measured number outside the range, below it.
By their numbers in this assay, from the lowest: compound 4; then compound 1; then compounds 2 and 3 (each within the scatter of the next).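

In this assay a substituent on this saturated ring carbon can lower the number as well as raise it: phenyl in place of ethyl gives a 99-fold lower number from compound 3 to compound 4 (2.00 log units; beyond the scatter) and phenyl in place of hydrogen gives an 8.9-fold lower number from compound 1 to compound 4 (0.95 log units; beyond the scatter) as a further result. Ethyl moves the number the opposite way, with an 11-fold higher number from compound 1 to compound 3 (1.05 log units; beyond the scatter) on the same core, so the outcome at this carbon depends on which group enters and not merely on a group being present. No supporting data on hand account for the contrast between phenyl and ethyl.

The compounds shown do not tell whether the fall needs an aromatic ring, which cyclohexyl or benzyl on this carbon would test. They also leave open whether phenyl has the same effect with the shorter chain of compound 2.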